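This account rests on a few compounds, and the source may have more. Where it says the series, first, only, none or still open, it means among the compounds named here.

Compounds measured so far:

compound 1, `CC(=O)c1ccc2c(c1)C(n1ccccc1=O)=CC(C)(C)O2`, gives 7.37 in a functional assay (aorta) with Rattus norvegicus as the target; a higher number here means a more potent compound, by a factor of ten per unit of this negative logarithm, a lower number a less potent compound
compound 2, `CC1(C)C=C(n2ccccc2=O)c2cc(C(=O)c3ccccc3F)ccc2O1`, gives 7.08 in this assay

Compound 2 has the lowest of the two numbers, yet its nearest neighbour, compound 1, lies only a number 0.29 log units lower from compound 1 to compound 2 (within the scatter) away, a gap within the scatter, so the two compounds cannot be ordered. Compound 3, `CC1(C)C=C(n2ccccc2=O)c2cc(C(=O)c3c(F)cccc3F)ccc2O1`, differs from compound 2 in one place: fluoro in place of hydrogen on an aromatic carbon. Within the data shown here, no measured step bears on this change. Among the measured compounds shown here, the only step known, a number 0.29 log units lower from compound 1 to compound 2 (within the scatter), exchanges the whole group on the carbonyl carbon and stays within the scatter; it does not speak to a second fluoro on the ring already bearing one. With nothing pointing in either direction, compound 3 is expected to stay close to compound 2, a step of a number 0.08 log units lower from compound 2 to compound 3 (within the scatter), none beyond the scatter. The estimate for compound 3 in this assay is 7, with a range from 6.5 to 7.5.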

Compound 3, logarithm of the reciprocal of the active concentration, log(1/C): 6.97
Beside the measured number, compound 3's estimate is 0.03 log units above it; the measured number falls inside the stated range.
By their numbers in this assay, from the lowest: compounds 3, 2 and 1 (each within the scatter of the next, the first and the last beyond it).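

In this assay, a second fluoro on the aromatic carbon ortho to a large group gives a number 0.11 log units lower from compound 2 to compound 3 (within the scatter) and so leaves the two compounds unordered: this position accepts the fluoro without a readable effect. Set against methyl on the carbonyl carbon, the 2,6-difluorophenyl group gives a number 0.40 log units lower from compound 1 to compound 3 (beyond the scatter) as the first step beyond the scatter in this series, a modest one, whereas the 2-fluorophenyl group stayed within it at a number 0.29 log units lower from compound 1 to compound 2 (within the scatter) for the same exchange. No measurement available here accounts for this small drift.

The compounds shown leave open whether a chlorine or a methoxy group on that same aromatic carbon would behave as the fluoro does. They also leave open where an unsubstituted phenyl group on the carbonyl carbon would fall relative to methyl.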